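The compounds below may be only part of what the source reports. "The series", "measured", "known", "first", "only" and "open" are said of these compounds alone.

Measured so far: compound 1 `CCCCOc1ccc2c(Cl)ccnc2c1` with 3050 nM in a functional assay on RKO cells (Homo sapiens) for cytotoxicity, read by MTT assay, with a stated time of 48 h (on this read-out higher numbers stand for weaker inhibition and lower numbers for stronger inhibition), and compound 2 `CCCCCCCCOc1ccc2c(Cl)ccnc2c1` with 3640 nM in this assay.

Compound 1 gives the lowest of the two numbers, but the gap to compound 2 is within the scatter: a 1.2-fold higher number from compound 1 to compound 2 (0.08 log units; within the scatter). The unmeasured compound 3 `Clc1ccnc2cc(OCc3ccccc3)ccc12` differs from compound 1 by phenyl in place of propyl on a saturated chain carbon bound to an oxygen on an aromatic ring. For the measured compounds named here, the only measured step, from compound 1 to compound 2, changes the chain beyond the oxygen and left the read-out flat; no measured step replaces chain by ring. For compound 3 no step beyond the scatter is expected, so compound 3 is estimated at 3000 nM (range 1200 nM to 7500 nM), an expected 1.0-fold lower number from compound 1 to compound 3 (0.01 log units; within the scatter).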

Compound 3, half-maximal inhibitory concentration: 2410 nM
For compound 3 the middle estimate is 1.2-fold (0.10 log units) above the measured one, and the stated range covers the measured number.
By their numbers in this assay, from the lowest: compounds 3, 1 and 2 (each within the scatter of the next).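

In this assay, the swap of chain for ring gives a 1.3-fold lower number from compound 1 to compound 3 (0.10 log units; within the scatter). A six-membered aromatic ring of carbon only is therefore tolerated on the saturated chain carbon bound to the oxygen, with no step beyond the scatter, which the two chain compounds could not show. Nothing available bears on why the read-out stays flat. As far as these compounds go, whether an amine or a carboxylic acid on the chain, or a substituted phenyl, would move the number beyond the scatter remains open.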